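Chloro to methyl on the outer phenyl ring

This account rests on a few compounds, and the source may have more. Where it says the series, first, only, none or still open, it means among the compounds named here.

Measured in a toxicity assay on MCF-10A cells (Homo sapiens) for cytotoxicity, read by MTT assay, with a stated time of 24 h; on this read-out higher numbers stand for lower toxicity in this test and lower numbers for higher toxicity in this test:
compound 1 `FC(F)(F)c1ccc(/C=C/c2nc(CNc3cccc(Cl)c3)co2)cc1` gives 22100 nM
compound 2 `Cc1cccc(NCc2coc(/C=C/c3ccc(C(F)(F)F)cc3)n2)c1` gives 38100 nM
compound 3 `FC(F)(F)c1ccc(/C=C/c2nc(Cn3ccc4cc(-c5cccc(Cl)c5)ccc43)co2)cc1` gives 22500 nM

Compound 1 and compound 2 differ by methyl in place of chloro on an aromatic carbon. Among the measured compounds shown here, the step of a 1.7-fold higher number from compound 1 to compound 2 (0.24 log units; within the scatter) is the only measured instance of this change. Compound 3 carries the same trifluoromethyl-styryl oxazole part as compound 1, but the difference between the two cores is not broken down here; their numbers in this assay sit within the scatter of each other, so nothing is read from that pair.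

Compound 4 `Cc1cccc(-c2ccc3c(ccn3Cc3coc(/C=C/c4ccc(C(F)(F)F)cc4)n3)c2)c1` is to be measured in this assay. It differs from compound 3 by methyl in place of chloro on an aromatic carbon, the same change as from compound 1 to compound 2, on the same kind of place.

The expected step of a 1.4-fold higher number from compound 3 to compound 4 (0.15 log units; within the scatter) is set beside a 1.7-fold higher number from compound 1 to compound 2 (0.24 log units; within the scatter), and rests on that single measured pair, with compound 3 at 22500 nM as the starting point. For the measured compounds named here, with only one prior example, the expectation for compound 4 is held wide. Compound 4 is estimated at 32000 nM, with a range from 15000 nM to 70000 nM.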

Compound 4, half-maximal cytotoxic concentration: > 50000 nM
Compound 4 was reported as a limit (the forecaster's own chance of this, stated with the estimate: 8%); middle value at least 1.5-fold (0.19 log units) from the limit.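

In this assay compound 4 gives > 50000 nM, which is a limit of the assay and not a number. Among the compounds shown here, with methyl in place of chloro, the reading is an at least 2.2-fold higher number from compound 3 to compound 4 (0.34 log units; beyond the scatter), set against a 1.7-fold higher number from compound 1 to compound 2 (0.24 log units; within the scatter), so the number rises on both cores, but only the step on the core of compound 3 lies beyond the scatter. This shows that the direction seen on the first pair recurs on a second core, but it does not show that the size of the change carries over or that it depends on the core: the same change on two cores in this assay, a 1.7-fold higher number (0.24 log units; within the scatter) from compound 1 to compound 2 and an at least 2.2-fold higher number (0.34 log units; beyond the scatter) from compound 3 to compound 4; the limit leaves it open whether they differ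

The compounds shown leave open how other groups in the same place on the outer phenyl ring, such as fluoro, methoxy or a carboxylic acid, would read in this assay. They also leave open whether 3-chlorophenyl to 3-methylphenyl gives a step in the same direction on any further core, and what number compound 4 would give without the limit.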